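From Hydroxy to Methoxy in a Growth-Inhibition Series

A few compounds are considered here, and "the series" means these few. Any claim that something is new, unique, unknown or untested is made for them only; others in the source may bear on it.

Within the data shown here, only two compounds with this shared core have numbers so far. In a functional assay on HT-29 cells (Homo sapiens) for inhibition, read by sulforhodamine B assay, with a stated time of 48 h (on this read-out higher numbers stand for weaker inhibition of growth and lower numbers for stronger inhibition of growth), compound 1 (`COc1ccc(/C=C/C2(C)C=CC(=O)O2)cc1OC`) gives 927000 nM as its result, and compound 2 (`CC1(/C=C/c2cccc(O)c2)C=CC(=O)O1`) gives 97400 nM as its result. That makes compound 2 the lower of the two numbers, and so the stronger inhibitor of growth, by a gap beyond the usual scatter.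

Compound 3 (`COc1cccc(/C=C/C2(C)C=CC(=O)O2)c1`) matches compound 2 except at one spot: methyl in place of hydrogen on an oxygen on an aromatic ring, so hydroxy becomes methoxy (methyl in place of hydrogen on an oxygen on an aromatic ring). Among the measured compounds shown here, no measured pair shows this change alone, which leaves only an indirect clue. Compound 1, at 927000 nM and carrying methoxy with no hydroxy, suggests that a step upward in this assay is to be expected, towards weaker inhibition and probably beyond the scatter, though compound 1 differs in more than one place. The estimated size is a 3.1-fold higher number from compound 2 to compound 3 (0.49 log units; beyond the scatter) as an expected rise. The expected value for compound 3 is 300000 nM (estimated range 100000 nM to 900000 nM).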

Compound 3, concentration for total growth inhibition: 17000 nM
The estimate for compound 3 lay 18-fold (1.25 log units) above the measured number; the measured number lies below the stated range.
By their numbers in this assay, from the lowest: compound 3; then compound 2; then compound 1.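

In this assay, putting a methyl on the oxygen of the aromatic ring turns hydroxy into methoxy and gives a 5.7-fold lower number from compound 2 to compound 3 (0.76 log units; beyond the scatter), so the change moves towards stronger inhibition of growth, and the free hydroxy is not required for activity in this small set. Compound 3 also stands well apart from the compound with two methoxy groups: hydrogen in place of a methoxy on an aromatic carbon gives a 55-fold lower number from compound 1 to compound 3 (1.74 log units; beyond the scatter), a larger step than the one from hydroxy to methoxy. Taken together, the two steps show that methoxy has no single effect in this series: compared with hydroxy, one methoxy goes with stronger inhibition, while the further methoxy of compound 1 goes with much weaker inhibition.

No measurement shown here gives a reason for either step. Going by these compounds, it remains open whether the gain continues with a longer chain on the same oxygen, such as ethoxy, or whether it survives when an amine takes the place of the oxygen group.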